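This account rests on a few compounds, and the source may have more. Where it says the series, first, only, none or still open, it means among the compounds named here.

The compounds here share one core and differ in a single group on an aromatic carbon. In a functional assay on MCF7 cells (Homo sapiens) for antiproliferative activity, read by sulforhodamine B assay, with a stated time of 72 h (a lower number here means a stronger inhibitor, a higher number a weaker inhibitor), compound 1 `O=C(/C=C/c1csc2ccccc12)c1cc(F)ccc1O`, carrying fluoro, gives > 10000 nM, a limit of the assay and not a number. Compound 2 `O=C(/C=C/c1csc2ccccc12)c1cc(Br)ccc1O`, carrying bromo, gives 1040 nM. Compound 3 `Cc1ccc(O)c(C(=O)/C=C/c2csc3ccccc23)c1`, carrying methyl, gives 7800 nM, the higher of the two actual numbers.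

Compound 4 `COc1ccc(O)c(C(=O)/C=C/c2csc3ccccc23)c1` has methoxy in place of methyl on an aromatic carbon, para to a hydroxy group (methoxy in place of methyl on an aromatic carbon).

Two measured steps show that this place can matter: an at least 9.6-fold lower number from compound 1 to compound 2 (0.98 log units; beyond the scatter), and a 7.5-fold higher number from compound 2 to compound 3 (0.88 log units; beyond the scatter). A third, an at least 1.2-fold lower number from compound 1 to compound 3 (0.10 log units; that floor lies within the scatter), has a floor within the scatter. None of them involves methoxy, so the expectation stays close to compound 3 at 7800 nM. The expected change is slight, and no shift beyond the scatter is expected: a 1.3-fold lower number from compound 3 to compound 4 (0.11 log units; within the scatter). For compound 4 the estimated value is 6000 nM, with an expected range from 2000 nM to 10000 nM.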

Compound 4, half-maximal inhibitory concentration: 750 nM
For compound 4 the middle estimate is 8.0-fold (0.90 log units) above the measured one; the measured number lies below the stated range.
By their numbers in this assay, from the lowest: compounds 4 and 2 (each within the scatter of the next); then compound 3. At a limit, above all of these: compound 1.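

In this assay, swapping one group at this place, para to a hydroxy group, can matter a great deal: a 10-fold lower number from compound 3 to compound 4 (1.02 log units; beyond the scatter), so methoxy and methyl are far from interchangeable here. Going by these compounds alone, until now bromo was the only group giving a clearly lower number, but methoxy cannot be told apart from it: a 1.4-fold lower number from compound 2 to compound 4 (0.14 log units; within the scatter). The comparison with fluoro, an at least 13-fold lower number from compound 1 to compound 4 (1.12 log units; beyond the scatter), gives only a floor, since compound 1 stands at a limit of the assay and not at a number: the limit of > 10000 nM in this assay, at which 1 of the 4 values shown sits.

With only fluoro, bromo, methyl and methoxy in view, nothing here explains why methoxy and bromo go together while methyl and fluoro do not. As far as these compounds go, whether ethoxy, a longer ether chain or an amine at this carbon would give a still lower number remains open.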